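A few compounds are considered here, and "the series" means these few. Any claim that something is new, unique, unknown or untested is made for them only; others in the source may bear on it.

Measured compounds:
- compound 1 `Cc1cc(O)cc(-c2nn(CC#N)cc2-c2ccnc(-c3ccc(Oc4ccccc4)cc3)c2)c1` — 5240 nM
- compound 2 `COc1cc(C)cc(-c2nn(CC#N)cc2-c2ccnc(-c3ccc(N(C)C)cc3)c2)c1` — 26600 nM

In a functional assay on HOP-92 cells (Homo sapiens) for inhibition, read by sulforhodamine B assay, with a stated time of 48 h (on this read-out lower numbers stand for stronger inhibition of growth and higher numbers for weaker inhibition of growth), compound 1 gives 5240 nM, while compound 2 gives 26600 nM, the higher of the two numbers and beyond the scatter from compound 1. Compound 2 thus stands as the weaker of the pair on this read-out. Compound 3 `Cc1cc(O)cc(-c2nn(CC#N)cc2-c2ccnc(-c3ccc(N(C)C)cc3)c2)c1` has not yet been measured. It differs from compound 2 in one place: hydrogen in place of methyl on an oxygen on an aromatic ring. Among the measured compounds shown here, compound 1 also carries the hydroxy group, but it differs from compound 3 at the other aryl group as well, so no single step isolates the hydroxy-for-methoxy change here. For the measured compounds named here, with no such step in hand, the direction is open; a modest move toward a lower number, within or near the scatter, is what compound 3 is expected to show, as a 1.8-fold lower number from compound 2 to compound 3 (0.25 log units; within the scatter). Compound 3 is therefore estimated at 15000 nM, with a range from 5000 nM to 40000 nM.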

Compound 3, concentration for total growth inhibition: 46800 nM
Compound 3: the middle estimate sits 3.1-fold (0.49 log units) below what was measured; the whole stated range lies below it.
By their numbers in this assay, from the lowest: compound 1; then compounds 2 and 3 (each within the scatter of the next).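

In this assay the swap of methoxy to hydroxy on the 3-methoxy-5-methylphenyl group gives a 1.8-fold higher number from compound 2 to compound 3 (0.25 log units; within the scatter) and so, with dimethylamino on the other aryl group, this change at the oxygen does not separate the two compounds. With the hydroxy group held in place, dimethylamino in place of phenoxy gives an 8.9-fold higher number from compound 1 to compound 3 (0.95 log units; beyond the scatter) and so, of the two single changes now readable, only this one at the aromatic carbon moves the number beyond the scatter. No supporting evidence accounts for either step.

Going by these compounds, whether the methoxy-to-hydroxy swap stays this small when phenoxy is present remains open. So does the outcome of an ethoxy group at the oxygen, or of a morpholine or a primary amine in place of dimethylamino.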